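Shortening the Side Chain of a Nucleoside Analogue

The source may report more compounds than this note shows. Statements on the series, on what has been measured and on what is new or still open speak of the compounds shown alone.

Measured so far in an ADME assay on HEL cells (Homo sapiens) for cytotoxicity, with a stated time of 3 days; a higher number here means that more compound is tolerated, a lower number that less compound is tolerated:
compound 1 `CCCCCCc1ccc(-c2cc3cn([C@H]4C[C@H](O)[C@@H](CO)O4)c(=O)nc3o2)nc1` gives > 100000 nM.
compound 2 `CCCCCCCCCCc1cc2cn([C@H]3C[C@H](O)[C@@H](CO)O3)c(=O)nc2o1` gives >= 130000 nM.
compound 3 `CCCCCCc1cnc(-c2cc3cn([C@H]4C[C@H](O)[C@@H](CO)O4)c(=O)nc3o2)nc1` gives > 100000 nM.

For compound 1 the result of > 100000 nM in this assay is a limit, not a number, as noted in the limit of > 100000 nM in this assay, at which 2 of the 3 values shown sit. For compound 2 the result of >= 130000 nM is likewise a limit, recorded in the limit of >= 130000 nM in this assay, at which 1 of the 3 values shown sits. For compound 3 the result of > 100000 nM is also a limit. Within the data shown here, compound 1 thus sits at the edge of what this assay can report, and no measured compound offers a number to compare against.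

Compound 4 `CCCCCc1ccc(-c2cc3cn([C@H]4C[C@H](O)[C@@H](CO)O4)c(=O)nc3o2)nc1` differs from compound 1 by hydrogen in place of methyl on a saturated chain carbon, five bonds along the chain from an aromatic carbon. Among the measured compounds shown here, no step between measured compounds is available here, so the step is expected to be none beyond the scatter, a number no higher from compound 1 to compound 4 (the limit leaves the size open). Compound 4 is therefore expected to give 100000 nM, between 50000 nM and 200000 nM, most probably again reported only as a limit.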

Compound 4, minimum cytotoxic concentration: > 100000 nM
Compound 4 ended at the assay's limit (the forecaster's own chance of this, stated with the estimate: 85%); the middle value sits exactly at the limit.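

The step between compound 1 and compound 4 cannot be read in this assay, because both results are limits: the limit of > 100000 nM in this assay, at which 3 of the 4 values shown sit.

The compounds shown leave open at what concentration any of them becomes cytotoxic to these cells.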